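A few compounds are considered here, and "the series" means these few. Any claim that something is new, unique, unknown or untested is made for them only; others in the source may bear on it.

The compounds measured so far:

Compound 1 `O=C1N=C(N2CCC[C@H]2C(=O)Nc2ccc3ncnc(Nc4cccc(Cl)c4)c3c2)S/C1=C/c1ccc(Br)s1`. In a functional assay on A549 cells (Homo sapiens) for antiproliferative activity, read by MTT assay (on this read-out higher numbers stand for weaker inhibition and lower numbers for stronger inhibition), compound 1 gives > 50000 nM, a limit of the assay and not a number.

Compound 2 `COc1ccc(/C=C2/SC(N3CCC[C@H]3C(=O)Nc3ccc4ncnc(Nc5cccc(Cl)c5)c4c3)=NC2=O)cc1`. In this assay compound 2 gives 31700 nM.

Compound 3 `O=C1N=C(N2CCC[C@H]2C(=O)Nc2ccc3ncnc(Nc4cccc(Cl)c4)c3c2)S/C1=C/c1cccc(Br)c1`. In this assay compound 3 gives > 50000 nM, again a limit of the assay rather than a number.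

Compound 1 therefore stands at the limit (the limit of > 50000 nM in this assay, at which 2 of the 3 values shown sit), with no number of its own. Compound 4 `COc1ccccc1/C=C1/SC(N2CCC[C@H]2C(=O)Nc2ccc3ncnc(Nc4cccc(Cl)c4)c3c2)=NC1=O` differs from compound 1 in one place: 2-methoxyphenyl in place of 5-bromothiophen-2-yl on a double-bonded chain carbon bound to a double-bonded ring carbon. The step that bears on it is an at least 1.5-fold lower number from compound 1 to compound 2 (0.19 log units; that floor lies within the scatter), which only reaches the scatter; an at least 1.5-fold higher number from compound 2 to compound 3 (0.19 log units; that floor lies within the scatter) runs the other way, and a step that the two limits leave unreadable from compound 1 to compound 3. Because the limit of > 50000 nM in this assay, at which 2 of the 3 values shown sit, holds most of the values, compound 4 is expected near the limit. Compound 4 is estimated at 40000 nM, between 18000 nM and 90000 nM, which as a step means an at least 1.2-fold lower number from compound 1 to compound 4 (0.09 log units; that floor lies within the scatter).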

Compound 4, half-maximal inhibitory concentration: > 50000 nM
Compound 4: a limit, no number; the forecaster's own chance of this, stated with the estimate: 50%; middle value at least 1.2-fold (0.09 log units) from the limit.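

In this assay compound 4 gives > 50000 nM, a limit of the assay and not a number, so a methoxy group on the phenyl ring at this place does not by itself give a measurable value. Moving the methoxy group gives an at least 1.5-fold higher number from compound 2 to compound 4 (0.19 log units; that floor lies within the scatter). The steps to compound 4 from compound 1 and compound 3 cannot be read, and the series now stands mostly at one point: the limit of > 50000 nM in this assay, at which 3 of the 4 values shown sit.

From the compounds shown here alone, the true potencies of compound 1, compound 3 and compound 4 remain unknown. Also open, going by these compounds, is whether an amine or a carboxylic acid on this phenyl ring would give a value clear of the limit.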